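Dichlorophenyl in Place of Methylphenyl in a Weakly Cytotoxic Series

This account rests on a few compounds, and the source may have more. Where it says the series, first, only, none or still open, it means among the compounds named here.

Compound 1, `COc1cccc(/C=C/C(=O)c2sc(Nc3ccc(Cl)cc3)nc2C)c1`: > 25000 nM
Compound 2, `Cc1nc(Nc2ccc(Cl)c(Cl)c2)sc1C(=O)/C=C/c1ccccc1`: 21500 nM
Compound 3, `COc1cccc(/C=C/C(=O)c2sc(Nc3ccccc3C)nc2C)c1`: > 25000 nM

In a functional assay on Bel-7402 cells (Homo sapiens) for cytotoxicity, read by MTT assay (on this read-out higher numbers stand for weaker inhibition and lower numbers for stronger inhibition), compound 3 gives > 25000 nM, which is a limit of the assay and not a number. Compound 1 likewise sits at the limit > 25000 nM. Compound 2 gives 21500 nM. Going by the values given here, the single measured step, a step that the two limits leave unreadable from compound 1 to compound 3, cannot be read because both of its ends sit at the limit of > 25000 nM in this assay, at which 2 of the 3 values shown sit.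

Compound 4, `COc1cccc(/C=C/C(=O)c2sc(Nc3ccc(Cl)c(Cl)c3)nc2C)c1`, differs from compound 3 by 3,4-dichlorophenyl in place of 2-methylphenyl on a nitrogen on an aromatic ring. Among the compounds with values here, no measured step covers this exchange; compound 2, which carries the same 3,4-dichlorophenyl group, shows only a weak value. The step is therefore expected to be an at least 1.0-fold lower number from compound 3 to compound 4 (0.01 log units; that floor lies within the scatter), nothing beyond the scatter. Compound 4 is expected at 24000 nM, between 8000 nM and 60000 nM, with a fair chance that this assay returns only a limit.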

Compound 4, half-maximal inhibitory concentration: > 25000 nM
Compound 4: only a limit was reported (the forecaster's own chance of this, stated with the estimate: 55%); middle value at least 1.0-fold (0.01 log units) away from the limit.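

In this assay compound 4 sits at a limit of the assay, so 3,4-dichlorophenyl on this nitrogen brings no readable value in the methoxy-bearing compounds. The steps to compound 4 from compound 1 and from compound 3 cannot be read, because both ends of each sit at one limit: the limit of > 25000 nM in this assay, at which 3 of the 4 values shown sit. Methoxy in place of hydrogen gives an at least 1.1-fold higher number from compound 2 to compound 4 (0.06 log units; that floor lies within the scatter), so this change shows no step beyond the scatter, though its true size may be larger. From the compounds shown here alone, whether an amine or a carboxylic acid on this aromatic ring would give a readable value remains open.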